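Halophenyl change from compound 2 to compound 3

A few compounds are considered here, and "the series" means these few. Any claim that something is new, unique, unknown or untested is made for them only; others in the source may bear on it.

compound 1 `NC1=NC2(CCSCC2)N(OCCCOc2ccc(Br)cc2)C(N)=N1` gives 740 nM
compound 2 `NC1=NC2(CCOCC2)N(OCCCOc2ccccc2Cl)C(N)=N1` gives 2700 nM

In a functional assay on A549 cells (Homo sapiens) for antiproliferative activity, read by MTT assay, with a stated time of 72 h (a higher number here means a weaker inhibitor, a lower number a stronger inhibitor), compound 2 holds the higher number of the two, and its gap to compound 1 lies beyond the scatter. Among the measured compounds shown here, compound 3 `NC1=NC2(CCOCC2)N(OCCCOc2cccc(Br)c2)C(N)=N1` has 3-bromophenyl in place of 2-chlorophenyl on an oxygen on a saturated carbon as its one difference from compound 2. For the measured compounds named here, no measured step covers this change, so no shift beyond the scatter is expected, with a slight drop the likelier direction. The estimated step is a 1.5-fold lower number from compound 2 to compound 3 (0.18 log units; within the scatter) and stays within the scatter. For compound 3 the estimated value is 1800 nM with an expected range from 600 nM to 5000 nM in this assay.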

Compound 3, half-maximal inhibitory concentration: 160 nM
Estimate against measurement, compound 3: 11-fold (1.05 log units) above; measured number below the stated range.
By their numbers in this assay, from the lowest: compound 3; then compound 1; then compound 2.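

In this assay, among the compounds shown here, the change to 3-bromophenyl in place of 2-chlorophenyl on an oxygen on a saturated carbon gives a 17-fold lower number from compound 2 to compound 3 (1.23 log units; beyond the scatter) and is the first single-place step, showing that this position responds strongly to the halophenyl group it carries. Halogen and its place on the ring change together in this step, so the step cannot be assigned to either alone. No measured evidence bears on this result. From the compounds shown here alone, whether 3-chlorophenyl or 2-bromophenyl would separate the two remains open. So does the outcome with an amine or a carboxylic acid on the phenyl ring.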